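Aryl urea series: chloro in place of trifluoromethyl

The source may report more compounds than this note shows. Statements on the series, on what has been measured and on what is new or still open speak of the compounds shown alone.

Compound 1 `COc1cc2cc(Oc3ccc(NC(=O)Nc4cccc(C(F)(F)F)c4)cc3)c(C)nc2cc1OC` carries a trifluoromethyl on the terminal phenyl of the urea; in a functional assay on U-251 cells (Homo sapiens) for inhibition, read by sulforhodamine B assay, with a stated time of 48 h (a lower number here means that less compound is tolerated, a higher number that more compound is tolerated), compound 1 gives 17000 nM. Compound 2 `COc1cc2cc(Oc3ccc(NC(=O)Nc4ccc(Cl)c(C(F)(F)F)c4)cc3)c(C)nc2cc1OC` adds a chloro to that same ring; in this assay compound 2 gives 12600 nM. The step of a 1.3-fold lower number from compound 1 to compound 2 (0.13 log units; within the scatter) is the only one measured so far. On the two numbers shown, compound 2 has the lower number, with compound 1 as its only neighbour and within the scatter of it.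

Compound 3 `COc1cc2cc(Oc3ccc(NC(=O)Nc4ccc(Cl)c(Cl)c4)cc3)c(C)nc2cc1OC` is the next point: chloro in place of trifluoromethyl on an aromatic carbon. Among the compounds with values here, no measured step bears directly on a trifluoromethyl-to-chloro exchange; the single step from compound 1 to compound 2 concerns a different change on the same ring and was within the scatter. With nothing in the data pointing in either direction, no step beyond the scatter is expected in this assay for compound 3, and the estimated step of no change at the digits printed from compound 2 to compound 3 (within the scatter) is taken as flat. Compound 3 is therefore expected at 12600 nM, with a range from 5000 nM to 32000 nM.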

Compound 3, concentration lethal to 50% of the cells: 26500 nM
Estimate against measurement, compound 3: 2.1-fold (0.32 log units) below; measured number inside the range.
By their numbers in this assay, from the lowest: compounds 2, 1 and 3 (each within the scatter of the next, the first and the last beyond it).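

In this assay, within the data shown here, the exchange of trifluoromethyl for chloro, on an aromatic carbon ortho to a chloro group, gives a 2.1-fold higher number from compound 2 to compound 3 (0.32 log units; beyond the scatter) and is the first step beyond the scatter, though a modest one; this position on the terminal phenyl therefore shows some response to the group it carries, which the earlier chloro addition did not show. Taken as a change of the whole terminal ring, 3,4-dichlorophenyl in place of 3-(trifluoromethyl)phenyl gives a 1.6-fold higher number from compound 1 to compound 3 (0.19 log units; within the scatter) and stays within the scatter, so the effect of the exchange is visible only against compound 2, and it rests on this single pair. No measurement at hand accounts for the step.

Still open, from the compounds shown here alone, is whether a nitrile, a methoxy or an amine at this position would move the number further from that of compound 2, or whether the step is particular to the trifluoromethyl and chloro pair. Also open, going by these compounds, is whether the same exchange would read the same way on a ring without the second chloro, as a 3-chlorophenyl urea set against compound 1.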